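Cytotoxicity of Three Amide Analogues on a Shared Core

The source may report more compounds than this note shows. Statements on the series, on what has been measured and on what is new or still open speak of the compounds shown alone.

Measured compounds:
compound 1 `CC(Cl)CC(=O)NC1=C(C#N)C(c2ccc(Cl)cc2Cl)C2=C(CCCC2=O)N1c1ccc(S(N)(=O)=O)cc1`, 60%
compound 2 `Cc1ccc(C(=O)NC2=C(C#N)C(c3ccc(Cl)cc3Cl)C3=C(CCCC3=O)N2c2ccc(S(N)(=O)=O)cc2)cc1`, 40%

Among the compounds with values here, in a functional assay on Ehrlich cells (Mus musculus) for cytotoxicity, read by trypan blue exclusion, with a stated time of 2 h, tested at 100 ug/mL (a higher number here means a stronger effect of the compound at the concentration tested, a lower number a weaker effect), compound 2 gives 40%, the lower of the two numbers; the only other measured compound, compound 1, gives 60%, and the step of a number 20 percentage points lower from compound 1 to compound 2 (beyond the scatter) lies beyond the scatter.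

Compound 3 `CC(=O)CC(=O)NC1=C(C#N)C(c2ccc(Cl)cc2Cl)C2=C(CCCC2=O)N1c1ccc(S(N)(=O)=O)cc1` is not yet measured. It differs from compound 2 as follows: 2-oxopropyl in place of 4-methylphenyl on a carbonyl carbon. Within the data shown here, the only measured step that bears on this change is a number 20 percentage points lower from compound 1 to compound 2 (beyond the scatter), where a short chain on the carbonyl carbon was swapped for the aromatic 4-methylphenyl and the reading fell modestly. The change to compound 3 runs the other way, replacing 4-methylphenyl with a short chain, here 2-oxopropyl, which is not the same chain as in compound 1, so the size of the reversal is uncertain. A moderate rise is therefore expected, estimated as a number 12 percentage points higher from compound 2 to compound 3 (beyond the scatter). Compound 3 is expected to give about 52%, with a likely range from 35% to 70%.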

Compound 3, a percentage reported as activity, at one concentration (the size of the read-out at that concentration, not a potency): 80%
Compound 3: middle estimate off by 28 percentage points, on the low side; measured number outside the range, above it.
By their numbers in this assay, from the lowest: compound 2; then compound 1; then compound 3.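

In this assay, putting 2-oxopropyl in place of 4-methylphenyl on the carbonyl carbon gives a number 40 percentage points higher from compound 2 to compound 3 (beyond the scatter) and is a large step, so this position can move the reading a long way in the upward direction too. The short chains are also not interchangeable here: acetyl in place of 1-chloroethyl on the saturated chain carbon bound to a carbonyl carbon gives a number 20 percentage points higher from compound 1 to compound 3 (beyond the scatter) and separates two ring-free groups, with the ring-bearing compound 2 lowest of the three. Nothing measured here gives a reason for either step.

The step from compound 2 to compound 3 removes the aromatic ring and adds a ketone carbonyl at once, so the compounds shown cannot say which of these changes matters, and a plain propyl chain or an unsubstituted phenyl would be needed to pull them apart. Going by these compounds, it also stays open how groups of another kind, such as an amine or a carboxylic acid on the same chain, would read, and how all of these would compare as potencies rather than as readings at one concentration.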